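The source may hold more compounds than are shown below. What is called first, only, known or untested is meant among the compounds shown, and "the series" means these compounds.

Measured compounds:
compound 1, `C#CCNC1CCc2c(SCCc3cccc(C)c3)cccc21`, 0.35 nM;
compound 2, `C#CCNC1CCc2c(SCc3cccc(F)c3)cccc21`, 1480 nM;
compound 3, `C#CCNC1CCc2c(SCc3ccc(C)cc3)cccc21`, 1560 nM.

All three were tested in an assay on isolated protein for inhibition of Amine oxidase [flavin-containing] B (Homo sapiens); a lower number here means a stronger inhibitor, a higher number a weaker inhibitor. Compound 1 gives the lowest number of the three: compound 2 gives 1480 nM, and compound 3 gives 1560 nM, both gaps from compound 1 well beyond the scatter. Compound 2 and compound 3 differ only in the aromatic ring carried on a saturated chain carbon bound to a sulfur, and that change gives a 1.1-fold higher number from compound 2 to compound 3 (0.02 log units; within the scatter).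

The unmeasured compound 4, `C#CCNC1CCc2c(SCCc3ccc(Cl)c(Cl)c3)cccc21`, is compound 1 with one change: 3,4-dichlorophenyl in place of 3-methylphenyl on a saturated chain carbon, two bonds along the chain from a sulfur.

For the measured compounds named here, only one measured step resembles this one, the swap of ring substituents between compound 2 and compound 3, which stayed within the scatter. It involves a shorter chain than in compound 1, so it bears on compound 4 only loosely. Given that precedent, the expectation is a step of modest size at most, a 2.3-fold higher number from compound 1 to compound 4 (0.36 log units; beyond the scatter), and compound 4 is estimated to give 0.8 nM in this assay, with a range from 0.2 nM to 4 nM.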

Compound 4, half-maximal inhibitory concentration: 3850 nM
For compound 4 the middle estimate is 4800-fold (3.68 log units) below the measured one; measured number outside the range, above it.
By their numbers in this assay, from the lowest: compound 1; then compounds 2 and 3 (each within the scatter of the next); then compound 4.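

In this assay, the ring at the end of this chain proves to matter greatly: 3,4-dichlorophenyl in place of 3-methylphenyl, on a saturated chain carbon two bonds along the chain from a sulfur, gives an 11000-fold higher number from compound 1 to compound 4 (4.04 log units; beyond the scatter) and turns a very strong inhibitor into a weak one. For the compounds shown here, the only earlier ring change, which gave a 1.1-fold higher number from compound 2 to compound 3 (0.02 log units; within the scatter) on a shorter chain, stayed within the scatter, so that result gave no sign that a change of ring substituents could have so large an effect. No measurement at hand accounts for this large step.

The compounds shown leave open whether the step comes from one chlorine or from the pair, a question that a 3-chlorophenyl or a 4-chlorophenyl group on the same chain would settle. They also leave open how an unsubstituted phenyl ring would behave at this position, and whether a longer chain would keep the low number of compound 1 or lose it.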